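Lengthening the Aminoalkyl Chain on a Shared Core

The source may report more compounds than this note shows. Statements on the series, on what has been measured and on what is new or still open speak of the compounds shown alone.

Compound 1 `CCN(CC)CCn1c(N)c(-c2nc3ccccc3[nH]2)c2nc(C#N)c(C#N)nc21`: 8950 nM in a functional assay on Raji cells (Homo sapiens) for antiproliferative activity, read by MTT assay, with a stated time of 48 h; on this read-out higher numbers stand for weaker inhibition and lower numbers for stronger inhibition
Compound 3 `CN1CCN(CCCn2c(N)c(-c3nc4ccccc4[nH]3)c3nc(C#N)c(C#N)nc32)CC1`: 2620 nM in this assay
Compound 2 `N#Cc1nc2c(-c3nc4ccccc4[nH]3)c(N)n(CCN3CCCC3)c2nc1C#N`: in this assay only a limit, > 50000 nM

Among the two numbers measured, compound 1 stands highest. Compound 3 sits below it, a change of a 3.4-fold lower number from compound 1 to compound 3 (0.53 log units; beyond the scatter). Compound 2 reached only (the limit of > 50000 nM in this assay, at which 1 of the 3 values shown sits). The change from compound 1 to compound 2 therefore reads an at least 5.5-fold higher number from compound 1 to compound 2 (0.74 log units; beyond the scatter), and that from compound 2 to compound 3 an at least 19-fold lower number from compound 2 to compound 3 (1.28 log units; beyond the scatter), so the group on the chain clearly matters on this read-out.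

Compound 4 `CCN(CC)CCCCn1c(N)c(-c2nc3ccccc3[nH]2)c2nc(C#N)c(C#N)nc21` differs from compound 1 in one place: 2-(diethylamino)ethyl in place of diethylamino on a saturated chain carbon, two bonds along the chain from an aromatic nitrogen. Among the compounds with values here, no measured step repeats this change. The nearest comparison is the step from compound 1 to compound 3, which kept a basic amine on the chain and gave a modest drop; the step to compound 2 shows that a different amine can instead weaken the inhibition strongly. Taken together, a small step downward, at most modest and possibly within the scatter, is expected. Compound 4 is estimated to give 6000 nM, with a range from 2000 nM to 20000 nM. This estimate means an expected step of a 1.5-fold lower number from compound 1 to compound 4 (0.17 log units; within the scatter).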

Compound 4, half-maximal inhibitory concentration: 2640 nM
Compound 4: middle estimate off by 2.3-fold (0.36 log units), on the high side; the measured number falls inside the stated range.
By their numbers in this assay, from the lowest: compounds 3 and 4 (each within the scatter of the next); then compound 1. At a limit, above all of these: compound 2.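

Within the data shown here, with the diethylamino group kept and only the chain lengthened, a 3.4-fold lower number from compound 1 to compound 4 (0.53 log units; beyond the scatter) in this assay, so chain length alone shifts this read-out, whereas the earlier steps all exchanged one amine for another. Compound 4 and compound 3 cannot be told apart, a 1.0-fold higher number from compound 3 to compound 4 (0.00 log units; within the scatter), so the 4-(diethylamino)butyl chain and the chain ending in 4-methylpiperazin-1-yl give matching numbers despite their different amines. The step to compound 4 from the pyrrolidin-1-yl compound, an at least 18-fold lower number from compound 2 to compound 4 (1.27 log units; beyond the scatter), starts from a limit and not a number: the limit of > 50000 nM in this assay, at which 1 of the 4 values shown sits.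

Among these compounds, whether a still longer chain ending in diethylamino would lower the number further remains open, since only two chain lengths carry that amine here. As far as these compounds go, it is also open whether lengthening the chain would restore activity with pyrrolidin-1-yl, or how a morpholine would behave at the chain end.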